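The compounds below may be only part of what the source reports. "The series", "measured", "known", "first", "only" and "open" are said of these compounds alone.

Of the compounds shown here, two with the same core have been tested in a functional assay for antagonist activity at Neuropeptide Y receptor type 2 (Homo sapiens); on this read-out higher numbers stand for weaker inhibition and lower numbers for stronger inhibition. Compound 1 `CCOC(=O)c1ccc(NC(=S)N2CCC(C(O)(c3ccccc3)c3ccccc3)CC2)cc1` gives 207 nM. Compound 2 `CN(C)C(=O)c1ccc(NC(=S)N2CCC(C(O)(c3ccccc3)c3ccccc3)CC2)cc1` gives 301 nM. Among the compounds with values here, the only step between them, a 1.5-fold higher number from compound 1 to compound 2 (0.16 log units; within the scatter), exchanges one group on a carbonyl carbon, so the two numbers stand within the usual scatter of each other.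

Compound 3 `CCOc1ccc(NC(=S)N2CCC(C(O)(c3ccccc3)c3ccccc3)CC2)c(F)c1` is not yet measured. It differs from compound 2 in a larger way: 4-ethoxy-2-fluorophenyl in place of 4-(dimethylcarbamoyl)phenyl on an amide-type nitrogen. Here the whole aryl group changes, and the carbonyl seen in both measured compounds is gone. Within the data shown here, no measured step covers such a swap, so the only guide is that the one known change on this aryl group, from compound 1 to compound 2, stayed within the scatter. Compound 3 is therefore expected near 400 nM, an expected step of a 1.3-fold higher number from compound 2 to compound 3 (0.12 log units; within the scatter), with a wide range from 100 nM to 1600 nM.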

Compound 3, half-maximal inhibitory concentration: 1350 nM
For compound 3 the middle estimate is 3.4-fold (0.53 log units) below the measured one; measured number inside the range.
By their numbers in this assay, from the lowest: compounds 1 and 2 (each within the scatter of the next); then compound 3.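

In this assay, the aryl group on the amide-type nitrogen turns out to matter: the earlier exchange on the carbonyl stayed within the scatter, but replacing the whole aryl group gives a 4.5-fold higher number from compound 2 to compound 3 (0.65 log units; beyond the scatter) and also a 6.5-fold higher number from compound 1 to compound 3 (0.81 log units; beyond the scatter) on the same core. Both aryl groups with a carbonyl, 4-(dimethylcarbamoyl)phenyl and 4-(ethoxycarbonyl)phenyl, thus give stronger inhibition than 4-ethoxy-2-fluorophenyl does. Nothing measured here explains this loss of inhibition.

The swap removes the carbonyl and adds a fluorine and an ether oxygen in one move, so these compounds cannot show which part accounts for the step. Still open, going by these compounds, is where a phenyl bearing only the ethoxy group, or an aryl group carrying a carboxylic acid or an amine, would fall.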